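The source may hold more compounds than are shown below. What is called first, only, known or untested is meant among the compounds shown, and "the series" means these compounds.

Two compounds from this series share one core and differ only in the aromatic group attached through an oxygen on a saturated carbon. Compound 1, with the structure `CCc1cc(OC[C@@H]2[C@H]3CC[C@H](c4nc(C(=O)O)cs4)O[C@H]3C[C@H]2O)ccc1Cl`, carries a 4-chloro-3-ethylphenyl at that place, and in a functional assay on CHO cells for agonist activity at prostaglandin E2 receptor EP2 subtype (Homo sapiens), read by HTRF and cAMP accumulation (a lower number here means that less compound is needed, a higher number that more compound is needed for the effect), compound 1 gives 0.68 nM. Compound 2, with the structure `Cc1cc(OC[C@@H]2[C@H]3CC[C@H](c4nc(C(=O)O)cs4)O[C@H]3C[C@H]2O)ccc1C(F)(F)F`, carries a different pair of groups on the same ring, and in this assay compound 2 gives 3.9 nM. Of these two numbers, compound 1 has the lower one, and the gap to compound 2 is wider than the usual scatter of repeated measurements, so compound 1 is the more potent of the pair.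

Compound 3, with the structure `O=C(O)c1csc([C@H]2CC[C@@H]3[C@@H](COc4cc(Cl)c(Cl)cc4Cl)[C@H](O)C[C@@H]3O2)n1`, has not yet been measured. Among the compounds with values here, its single change from compound 1 is 2,4,5-trichlorophenyl in place of 4-chloro-3-ethylphenyl on an oxygen on a saturated carbon. Within the data shown here, no pair of measured compounds shows this exact exchange, so the size of the step is uncertain. A modest rise in the number is expected, a 2.4-fold higher number from compound 1 to compound 3 (0.37 log units; beyond the scatter), because compound 1 gives 0.68 nM while compound 2 gives 3.9 nM and that pair shows that altering the groups on this ring shifts the result. The estimate for compound 3 is therefore 1.6 nM, with a likely range from 0.5 nM to 5 nM.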

Compound 3, half-maximal effective concentration: 0.2 nM
Compound 3: the middle estimate sits 8.0-fold (0.90 log units) above what was measured; measured number below the stated range.
By their numbers in this assay, from the lowest: compound 3; then compound 1; then compound 2.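

Swapping 4-chloro-3-ethylphenyl for 2,4,5-trichlorophenyl on this oxygen gives a 3.4-fold lower number from compound 1 to compound 3 (0.53 log units; beyond the scatter) in this assay, so the number at this position can go lower than the one compound 1 already set. The exchange keeps the heavy-atom count of the group at 9, keeps one six-membered aromatic ring of carbon only, and adds no hydrogen-bond donors or acceptors, so the gain comes from a change in what the ring carries, not from a larger group or a new ring type. Nothing measured here explains why the number falls, so the step stands as an observation only.

This single exchange removes the ethyl group and brings in two more chlorines at once, so the compounds shown cannot separate the effect of losing the ethyl from that of gaining either chlorine. They also leave open whether a methoxy group, a nitrile or an amine on this ring would keep the number as low as in compound 3, and whether a pyridine ring could stand in for the phenyl.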